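Compound 4: 4-fluorophenyl replaces 2-(trifluoromethoxy)phenyl

The compounds below may be only part of what the source reports. "The series", "measured", "known", "first", "only" and "open" are said of these compounds alone.

Compound 3 `Cc1cc(=O)n(-c2ccccc2OC(F)(F)F)nc1C(=O)Nc1ccc(Oc2ncnc3sccc23)c(F)c1` stands at the weak end of the three measured compounds. In a functional assay on A549 cells (Homo sapiens) for cytotoxicity, read by MTT assay, with a stated time of 72 h (a lower number here means a stronger inhibitor, a higher number a weaker inhibitor), compound 3 gives only a limit of the assay, > 40000 nM; this is the limit of > 40000 nM in this assay, at which 1 of the 3 values shown sits. Among the measured compounds shown here, compound 2 `Cc1cc(=O)n(-c2ccccc2C(F)(F)F)nc1C(=O)Nc1ccc(Oc2ncnc3sccc23)c(F)c1` gives 16300 nM in this assay, and an at least 2.4-fold higher number from compound 2 to compound 3 (0.38 log units; beyond the scatter) is the only measured step that touches the group on the aromatic nitrogen. Compound 1 `Cc1cc(=O)n(-c2ccc(F)cc2)nc1C(=O)Nc1ccc(Oc2ncnc3ccsc23)c(F)c1`, which also carries 4-fluorophenyl on that nitrogen, gives 580 nM in this assay. Compound 4 `Cc1cc(=O)n(-c2ccc(F)cc2)nc1C(=O)Nc1ccc(Oc2ncnc3sccc23)c(F)c1` differs from compound 3 by 4-fluorophenyl in place of 2-(trifluoromethoxy)phenyl on an aromatic nitrogen. For the measured compounds named here, the one measured step is large and beyond the scatter, but it concerns a different pair of groups, and no step links compound 1 with compound 4. A clear fall in the number is nevertheless expected, an at least 26-fold lower number from compound 3 to compound 4 (1.42 log units; beyond the scatter). Compound 4 is estimated at 1500 nM, between 300 nM and 8000 nM.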

Compound 4, half-maximal inhibitory concentration: 2620 nM
Estimate against measurement, compound 4: 1.7-fold (0.24 log units) below; low and high end bracket the measured number.
By their numbers in this assay, from the lowest: compound 1; then compound 4; then compound 2. At a limit, above all of these: compound 3.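

At the aromatic nitrogen, 4-fluorophenyl gives a lower number than either group it replaces in this assay (a 6.2-fold lower number from compound 2 to compound 4 (0.79 log units; beyond the scatter)) and (an at least 15-fold lower number from compound 3 to compound 4 (1.18 log units; beyond the scatter)). The second of these steps starts from a limit for compound 3: the limit of > 40000 nM in this assay, at which 1 of the 4 values shown sits. With 4-fluorophenyl held constant, the group on the oxygen also matters (a 4.5-fold higher number from compound 1 to compound 4 (0.65 log units; beyond the scatter)).

From the compounds shown here alone, these pairs change both the substituent and where it sits, so the contribution of each stays open. Also open, going by these compounds, is how a phenyl bearing an amine or a carboxylic acid would read on this nitrogen.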